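Moving from a furan to a substituted phenyl on the amine side

A few compounds are considered here, and "the series" means these few. Any claim that something is new, unique, unknown or untested is made for them only; others in the source may bear on it.

Compound 1 `CC(C)Cc1ccc2c(NCCCNCc3ccco3)ccnc2c1` gives 23 10^-6 cm/s in an ADME assay for permeability, using PAMPA, with a stated time of 30 min, at pH 7.4; a lower number here means that the compound crosses the layer more slowly, a higher number that the compound crosses the layer faster. Compound 3 `c1coc(CNCCCNc2ccnc3cc(CC4CCCCC4)ccc23)c1` gives 23 10^-6 cm/s, and the two stand level at the digits shown, with no change at the digits printed from compound 1 to compound 3 (within the scatter). Among the compounds with values here, compound 2 `Fc1ccc(-c2ccc3c(NCCCNCc4ccco4)ccnc3c2)cc1` gives 237 10^-6 cm/s, so compound 1 sits with compound 3 at the lowest of the three numbers, and the only large step in the set is a 10-fold higher number from compound 1 to compound 2 (1.01 log units; beyond the scatter), answered by a 10-fold lower number from compound 2 to compound 3 (1.01 log units; beyond the scatter).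

Compound 4 `COc1cccc(CNCCCNc2ccnc3cc(CC(C)C)ccc23)c1O` differs from compound 1 in a different part of the molecule: 2-hydroxy-3-methoxyphenyl in place of furan-2-yl on a saturated chain carbon bound to an amine nitrogen. None of the three measured steps touches this carbon; all of them change the group on the aromatic carbon of the shared core, so they do not bear directly on the change from compound 1 to compound 4. Within the data shown here, with no direct precedent, the author expects a step that stays within, or only slightly beyond, the scatter, and leans toward a lower number, a 1.5-fold lower number from compound 1 to compound 4 (0.19 log units; within the scatter). The estimate for compound 4 in this assay is therefore 15 10^-6 cm/s, in the range 5 10^-6 cm/s to 45 10^-6 cm/s.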

Compound 4, apparent permeability: 23 10^-6 cm/s
Compound 4: middle estimate off by 1.5-fold (0.19 log units), on the low side; the measured number falls inside the stated range.
By their numbers in this assay, from the lowest: compounds 1, 3 and 4 (each within the scatter of the next); then compound 2.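

In this assay, putting 2-hydroxy-3-methoxyphenyl in place of furan-2-yl on a saturated chain carbon bound to an amine nitrogen gives no change at the digits printed from compound 1 to compound 4 (within the scatter), the first reading at this position among the compounds shown. The entering group brings a six-membered aromatic ring of carbon only and a hydrogen-bond donor that furan-2-yl lacks, yet this step stays within the scatter, whereas replacing isobutyl on the aromatic carbon gives a 10-fold higher number from compound 1 to compound 2 (1.01 log units; beyond the scatter) as the large step from compound 1. No measurement shown offers an explanation for this result.

From the compounds shown here alone, only one replacement at this carbon can be read, with isobutyl on the aromatic carbon, so whether it would also leave the number unmoved alongside the 4-fluorophenyl of compound 2 remains open. Also open, going by these compounds, is how an unsubstituted phenyl or a carboxylic acid at this carbon would read.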